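The source may hold more compounds than are shown below. What is called first, only, known or untested is meant among the compounds shown, and "the series" means these compounds.

Measured compounds:
compound 1, `CC1CCN(c2c(S(=O)(=O)c3cc(F)cc(F)c3)cnc3cc(F)ccc23)CC1`, 77%
compound 2, `Cc1cc(C)cc(S(=O)(=O)c2cnc3cc(F)ccc3c2N2CCC(C)CC2)c1`, 80%
compound 3, `Cc1ccc(S(=O)(=O)c2cnc3cc(F)ccc3c2N2CCC(C)CC2)cc1Cl`, 93%

In an assay on isolated protein for displacement of a labelled ligand from metabotropic glutamate receptor 5 (Homo sapiens), with a stated time of 60 min, tested at 1 uM (on this read-out lower numbers stand for less inhibition and higher numbers for more inhibition at the one concentration tested (going by the name of the read-out)), compound 3 stands highest of the three numbers. Its nearest neighbour is compound 2, with a number 13 percentage points higher from compound 2 to compound 3 (beyond the scatter), and the furthest is compound 1, with a number 16 percentage points higher from compound 1 to compound 3 (beyond the scatter). Compound 1 and compound 2 lie within the scatter of each other, as a number 3 percentage points higher from compound 1 to compound 2 (within the scatter) shows.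

Compound 4, `CC1CCN(c2c(S(=O)(=O)c3cccc(C#N)c3)cnc3cc(F)ccc23)CC1`, is not yet measured in this assay. It differs from compound 3 in one place: 3-cyanophenyl in place of 3-chloro-4-methylphenyl on a sulfonyl sulfur. All three measured steps also exchange the aryl group on the sulfonyl sulfur, so all bear on this change; they span a modest range, and the 3-chloro-4-methylphenyl of compound 3 stands above both other aryl groups through a number 16 percentage points higher from compound 1 to compound 3 (beyond the scatter) and a number 13 percentage points higher from compound 2 to compound 3 (beyond the scatter). Within the data shown here, no measured compound carries a nitrile on that aryl group, so the direction for compound 4 rests only on the observation that the other two aryl groups gave lower numbers than compound 3.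

Compound 4 is therefore expected to show a modest downward step, a number 15 percentage points lower from compound 3 to compound 4 (beyond the scatter), in this assay. The estimated value of compound 4 in this assay is 78%, with a range from 55% to 92%.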

Compound 4, a percentage reported as inhibition, at one concentration (the size of the read-out at that concentration, not a potency): 92%
The estimate for compound 4 lay 14 percentage points below the measured number, within the range that was stated.
By their numbers in this assay, from the lowest: compounds 1 and 2 (each within the scatter of the next); then compounds 4 and 3 (each within the scatter of the next).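

In this assay, exchanging 3-chloro-4-methylphenyl for 3-cyanophenyl on the sulfonyl sulfur gives a number 1 percentage points lower from compound 3 to compound 4 (within the scatter), so the read-out does not separate these two aryl groups, and the top of this short series no longer rests on 3-chloro-4-methylphenyl alone. The 3-cyanophenyl group also stands clear of the other two aryl groups, with a number 12 percentage points higher from compound 2 to compound 4 (beyond the scatter) and a number 15 percentage points higher from compound 1 to compound 4 (beyond the scatter), which shows that among these four compounds a high number at this position requires neither the chlorine nor the methyl of compound 3. The compounds shown offer no evidence on why the nitrile-bearing ring matches 3-chloro-4-methylphenyl here.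

A percentage at a single concentration cannot show whether compound 3 and compound 4 differ in potency, as both sit high on this read-out and a full concentration series would be needed to tell them apart. On these data alone, it also remains open whether the result is particular to the nitrile, or whether a methoxy group, a primary amide or a carboxylic acid in its place on the phenyl ring would hold the number in this assay.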